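Swapping in 4-nitrophenyl near the assay's limit

This account rests on a few compounds, and the source may have more. Where it says the series, first, only, none or still open, it means among the compounds named here.

In a functional assay on Jurkat cells (Homo sapiens) (on this read-out higher numbers stand for weaker inhibition and lower numbers for stronger inhibition), compound 3 `CC(=O)Nc1cccc(OCC(=O)[C@H](CC(=O)O)NC(=O)[C@@H](NC(=O)COc2cccc3ccccc23)C(C)C)c1` gives > 100000 nM, which is a limit of the assay and not a measured number. Compound 1 `CC(C)[C@H](NC(=O)COc1cccc2ccccc12)C(=O)N[C@@H](CC(=O)O)C(=O)COc1cccc2ccccc12` gives > 100000 nM, also a limit. Within the data shown here, compound 2 `CC(C)[C@H](NC(=O)COc1cccc2ccccc12)C(=O)N[C@@H](CC(=O)O)C(=O)COc1ccc(-c2ccccc2)cc1` gives 87900 nM, the only true number so far. The picture so far is the limit of > 100000 nM in this assay, at which 2 of the 3 values shown sit.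

Compound 4 `CC(C)[C@H](NC(=O)COc1cccc2ccccc12)C(=O)N[C@@H](CC(=O)O)C(=O)COc1ccc([N+](=O)[O-])cc1` differs from compound 3 at one place, where 4-nitrophenyl replaces 3-acetamidophenyl on an oxygen on a saturated carbon: 4-nitrophenyl in place of 3-acetamidophenyl on an oxygen on a saturated carbon.

Three measured steps changed the group at this same place. The first, an at least 1.1-fold lower number from compound 1 to compound 2 (0.05 log units; that floor lies within the scatter), is only a floor within the scatter. The second, an at least 1.1-fold higher number from compound 2 to compound 3 (0.05 log units; that floor lies within the scatter), is likewise such a floor. The third, a step that the two limits leave unreadable from compound 1 to compound 3, cannot be read at all. None of these three compounds therefore shows a change at this place beyond the scatter, so none is expected here in this assay. The estimated step is a number no higher from compound 3 to compound 4 (the limit leaves the size open), with no direction expected. For compound 4 the estimate is 100000 nM, with an expected range from 40000 nM to 250000 nM, and a report of only a limit is likely.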

Compound 4, half-maximal inhibitory concentration: > 100000 nM
Compound 4 ended at the assay's limit (the forecaster's own chance of this, stated with the estimate: 70%); the middle value sits exactly at the limit.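

In this assay, nitro in place of phenyl on an aromatic carbon gives an at least 1.1-fold higher number from compound 2 to compound 4 (0.05 log units; that floor lies within the scatter). The steps from compound 3 and from compound 1 to compound 4 cannot be read, as each has a limit at both ends. With 4-nitrophenyl, a fourth group on this oxygen leaves the series where it stood: the limit of > 100000 nM in this assay, at which 3 of the 4 values shown sit.

Going by these compounds, whether any group at this place can bring a value well clear of the limit stays open, as does how much this place matters at all, since compound 2 alone gives a true number. What an amine or a longer chain would do on that aromatic carbon in place of nitro cannot be told from these compounds.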